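Changing the amine at the end of the chain

This account rests on a few compounds, and the source may have more. Where it says the series, first, only, none or still open, it means among the compounds named here.

Compound 3 `CN1CCN(CCCCOc2c(OCc3ccccc3)cc3oc(-c4ccccc4)cc(=O)c3c2O)CC1` gives 7200 nM in a functional assay on BCG823 cells (Homo sapiens) for antiproliferative activity, read by MTT assay, with a stated time of 48 h (on this read-out lower numbers stand for stronger inhibition and higher numbers for weaker inhibition), the highest of the two numbers that were obtained. Compound 1 `O=c1cc(-c2ccccc2)oc2cc(OCc3ccccc3)c(OCCCN3CCCCC3)c(O)c12` gives 4600 nM in this assay, and the difference a 1.6-fold higher number from compound 1 to compound 3 (0.19 log units; within the scatter) is small. Compound 2 `O=c1cc(-c2ccccc2)oc2cc(OCc3ccccc3)c(OCCCN3CCCC3)c(O)c12` reaches only a limit of this assay, > 100000 nM, at the limit of > 100000 nM in this assay, at which 1 of the 3 values shown sits. Compound 4 `CCN(CC)CCCCOc1c(OCc2ccccc2)cc2oc(-c3ccccc3)cc(=O)c2c1O` has not been measured; it differs from compound 3 by diethylamino in place of 4-methylpiperazin-1-yl on a saturated chain carbon, four bonds along the chain from an oxygen on an aromatic ring. The measured steps show that the amine at the chain end matters: an at least 21-fold higher number from compound 1 to compound 2 (1.33 log units; beyond the scatter) is large, while a 1.6-fold higher number from compound 1 to compound 3 (0.19 log units; within the scatter) is not. For the measured compounds named here, the change to an open-chain amine has no direct counterpart among the measured compounds, so the direction is uncertain. Compound 4 is expected to land near compound 3, with the step of a 1.3-fold higher number from compound 3 to compound 4 (0.10 log units; within the scatter) estimated as modest but with a wide spread. The estimate for compound 4 in this assay is 9000 nM, within a range from 2500 nM to 50000 nM.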

Compound 4, half-maximal inhibitory concentration: 4200 nM
Estimate against measurement, compound 4: 2.1-fold (0.33 log units) above; the range from low to high includes it.
By their numbers in this assay, from the lowest: compounds 4, 1 and 3 (each within the scatter of the next). At a limit, above all of these: compound 2.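

An open-chain amine at the chain end serves as well here as the ring amines: in this assay, the values cannot be told apart, with a 1.7-fold lower number from compound 3 to compound 4 (0.23 log units; within the scatter) and a 1.1-fold lower number from compound 1 to compound 4 (0.04 log units; within the scatter). A ring at the chain end is therefore not needed for activity in this range, and among the four amines shown only the pyrrolidin-1-yl of compound 2 stands apart, with an at least 23-fold lower number from compound 2 to compound 4 (1.37 log units; beyond the scatter). The value of compound 2 is a limit, not a number: the limit of > 100000 nM in this assay, at which 1 of the 4 values shown sits.

As far as these compounds go, it remains open whether pyrrolidin-1-yl would stand apart in the same way on the chain of compound 4, or whether a longer chain would change the picture. From the compounds shown here alone, it is equally open how other amines, such as morpholin-4-yl or dimethylamino, would behave at this chain end.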